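Swapping the aryl group of a thiosemicarbazone: chlorophenyl to furanyl

The source may hold more compounds than are shown below. What is called first, only, known or untested is meant among the compounds shown, and "the series" means these compounds.

Measured so far:
compound 1, `CC1=CC[C@H](C(C)(C)NC(=S)N/N=C/c2ccccc2O)CC1`, 11800 nM
compound 2, `CC1=CC[C@H](C(C)(C)NC(=S)N/N=C/c2ccccc2Cl)CC1`, 83600 nM

In a functional assay on OVCAR-3 cells (Homo sapiens) for inhibition, read by sulforhodamine B assay, with a stated time of 48 h (a lower number here means a stronger inhibitor of growth, a higher number a weaker inhibitor of growth), compound 2 gives the highest of the two numbers, with a 7.1-fold higher number from compound 1 to compound 2 (0.85 log units; beyond the scatter). Compound 3, `CC1=CC[C@H](C(C)(C)NC(=S)N/N=C/c2ccco2)CC1`, differs from compound 2 by furan-2-yl in place of 2-chlorophenyl on a carbon with a double bond to nitrogen. Among the compounds with values here, no measured step covers this change; the only step, from hydroxy to chloro, concerns a group on the ring that now leaves entirely. With a single indirect step, a modest shift toward a lower number is expected, estimated as a 2.1-fold lower number from compound 2 to compound 3 (0.32 log units; beyond the scatter). Compound 3 is expected to give 40000 nM, in the range 10000 nM to 150000 nM.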

Compound 3, concentration for total growth inhibition: 13800 nM
Compound 3: the middle estimate sits 2.9-fold (0.46 log units) above what was measured; measured number inside the range.
By their numbers in this assay, from the lowest: compounds 1 and 3 (each within the scatter of the next); then compound 2.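

In this assay, furan-2-yl in place of 2-chlorophenyl gives a 6.1-fold lower number from compound 2 to compound 3 (0.78 log units; beyond the scatter) and so shows that the carbon with a double bond to nitrogen can carry a five-membered aromatic ring with a lower number. Furan-2-yl in place of 2-hydroxyphenyl gives a 1.2-fold higher number from compound 1 to compound 3 (0.07 log units; within the scatter), so compound 1 and compound 3 cannot be ranked against each other. Nothing available explains these results. Still open, from the compounds shown here alone, is how an amine or a methoxy group on the phenyl ring would compare with the hydroxy of compound 1.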